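This account rests on a few compounds, and the source may have more. Where it says the series, first, only, none or still open, it means among the compounds named here.

Measured compounds:
- compound 1, `COc1ccc(C(=O)NNC(=S)Nc2csc(-c3ccccc3)c2)cc1`, giving 35000 nM in a functional assay on Hs 683 cells (Homo sapiens) for inhibition, read by colorimetric assay and MTT assay, with a stated time of 72 h; on this read-out higher numbers stand for weaker inhibition and lower numbers for stronger inhibition
- compound 2, `COc1ccc(C(=O)NNC(=S)Nc2csc(-c3ccc(C)cc3)c2)cc1`, which in this assay gives 12000 nM
- compound 3, `COc1cc(OC)cc(C(=O)NNC(=S)Nc2csc(-c3ccccc3)c2)c1`, which in this assay gives 42000 nM

Compound 1 and compound 2 differ in one place: methyl in place of hydrogen on an aromatic carbon. That change brought a 2.9-fold lower number from compound 1 to compound 2 (0.46 log units; beyond the scatter). Compound 3 has a different core from compound 1; the difference between the two cores is not broken down here. Compound 4, `COc1cc(OC)cc(C(=O)NNC(=S)Nc2csc(-c3ccc(C)cc3)c2)c1`, is not yet measured. It differs from compound 3 by methyl in place of hydrogen on an aromatic carbon, the same change that separates compound 1 from compound 2. Resting on a 2.9-fold lower number from compound 1 to compound 2 (0.46 log units; beyond the scatter), a step of similar size is expected for a 2.8-fold lower number from compound 3 to compound 4 (0.45 log units; beyond the scatter) in this assay. Compound 4 is therefore estimated at 15000 nM, with an expected range from 7000 nM to 35000 nM.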

Compound 4, half-maximal inhibitory concentration: 37000 nM
The estimate for compound 4 lay 2.5-fold (0.39 log units) below the measured number; the measured number lies above the stated range.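

In this assay, the same methyl addition on the core of compound 3 gave a 1.1-fold lower number from compound 3 to compound 4 (0.06 log units; within the scatter), so the clear step seen on the core of compound 1 did not show up as a clear step here. Set side by side, the two steps still do not differ by more than the scatter allows: the same change on two cores in this assay, a 2.9-fold lower number (0.46 log units; beyond the scatter) from compound 1 to compound 2 and a 1.1-fold lower number (0.06 log units; within the scatter) from compound 3 to compound 4, 2.6-fold (0.41 log units) apart, within the scatter of two such steps. Going by these compounds alone, with only one pair on each core, this neither shows that the change carries over reliably nor that the core alters its effect.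

The compounds shown leave open what other groups in the same place, such as an amine or a carboxylic acid, would do on either core.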